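A few compounds are considered here, and "the series" means these few. Any claim that something is new, unique, unknown or untested is made for them only; others in the source may bear on it.

In a functional assay on SMMC-7721 cells (Homo sapiens) for antiproliferative activity, read by MTT assay, with a stated time of 72 h (on this read-out lower numbers stand for stronger inhibition and higher numbers for weaker inhibition), three compounds that share one core have been measured so far. Compound 1 `O=C(N/N=C/c1ccco1)c1cccc(S(=O)(=O)N2CCOCC2)c1` gives > 100000 nM, which is a limit of the assay and not a number. Compound 2 `O=C(N/N=C/c1ccccc1O)c1cccc(S(=O)(=O)N2CCOCC2)c1` gives 12100 nM, the lowest of the two actual numbers, and compound 3 `CCN(CC)c1ccc(/C=N/NC(=O)c2cccc(S(=O)(=O)N3CCOCC3)c2)c(O)c1` gives 27100 nM.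

The next compound, compound 4 `O=C(N/N=C/c1cc(Cl)ccc1O)c1cccc(S(=O)(=O)N2CCOCC2)c1`, differs from compound 2 in one place: chloro in place of hydrogen on an aromatic carbon, para to a hydroxy group, so that 2-hydroxyphenyl becomes 5-chloro-2-hydroxyphenyl (chloro in place of hydrogen on an aromatic carbon).

Within the data shown here, two measured steps bear on this change. The closer one is a 2.2-fold higher number from compound 2 to compound 3 (0.35 log units; beyond the scatter), where diethylamino replaces hydrogen on an aromatic carbon of the same ring. Among the measured compounds shown here, it is a modest step, and it is the only measured example of adding a group to this ring. The larger one is an at least 8.2-fold lower number from compound 1 to compound 2 (0.91 log units; beyond the scatter), but it exchanges furan-2-yl for 2-hydroxyphenyl and starts from a limit (the limit of > 100000 nM in this assay, at which 1 of the 3 values shown sits), so it says little about adding a single chloro.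

From the compounds shown here alone, on this evidence, no step beyond the scatter is expected in this assay, and the direction remains open. The expected change is a 1.2-fold lower number from compound 2 to compound 4 (0.08 log units; within the scatter). For compound 4, the estimated value is 10000 nM, with an expected range from 3500 nM to 30000 nM.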

Compound 4, half-maximal inhibitory concentration: 6820 nM
Compound 4: the middle estimate sits 1.5-fold (0.17 log units) above what was measured; low and high end bracket the measured number.
By their numbers in this assay, from the lowest: compounds 4 and 2 (each within the scatter of the next); then compound 3. At a limit, above all of these: compound 1.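

In this assay, chloro on the aromatic carbon para to a hydroxy group gives a 1.8-fold lower number from compound 2 to compound 4 (0.25 log units; within the scatter), so compound 2 and compound 4 cannot be told apart here, and this place on the ring takes a single chlorine without a step beyond the scatter. Until now, the only group shown entering this ring was the diethylamino group of compound 3, with a 2.2-fold higher number from compound 2 to compound 3 (0.35 log units; beyond the scatter), and chloro now gives a second example, on a different carbon of the ring, whose step stays within the scatter. Exchanging furan-2-yl for 5-chloro-2-hydroxyphenyl gives an at least 14-fold lower number from compound 1 to compound 4 (1.16 log units; beyond the scatter), a large step, but it starts from compound 1, whose value is a limit and not a number: the limit of > 100000 nM in this assay, at which 1 of the 4 values shown sits.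

The compounds shown leave open whether bromo, a methoxy group, an amine or a carboxylic acid on this same carbon would move the number beyond the scatter in either direction. Among these compounds, they also leave open what the hydroxy group contributes once chloro is present, as compound 4, the only compound here with chloro, carries both groups.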